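This account rests on a few compounds, and the source may have more. Where it says the series, first, only, none or still open, it means among the compounds named here.

Compound 3 `COc1cc(C(=O)N2CCC(O)C(C)C2)cc2nc(NCc3cncc(Cl)c3)oc12` gives the highest number of the three compounds measured in an assay on isolated protein for inhibition of thyroid hormone receptor beta (Homo sapiens), read by fluorescence, with a stated time of 30 min (a lower number here means a stronger inhibitor, a higher number a weaker inhibitor), at 7200 nM. Its nearest neighbour is compound 2 `COc1cc(C(=O)N2CCC(O)C(C)C2)cc2nc(NCc3cc(Cl)ccn3)oc12`, which in this assay gives 190 nM, and the furthest is compound 1 `COc1cc(C(=O)N2CCC(O)C(C)C2)cc2nc(NCc3cccc(Cl)c3)oc12`, which gives 25 nM. The measured steps are a 7.6-fold higher number from compound 1 to compound 2 (0.88 log units; beyond the scatter), a 290-fold higher number from compound 1 to compound 3 (2.46 log units; beyond the scatter) and a 38-fold higher number from compound 2 to compound 3 (1.58 log units; beyond the scatter), so the three compounds differ only in the six-membered ring on the saturated chain carbon bound to a nitrogen on the shared core, and that ring alone accounts for the whole spread.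

Compound 4 `COc1cc(C(=O)N2CCC(O)C(C)C2)cc2nc(NCc3ccnc(Cl)c3)oc12` has not been measured in this assay. The change from compound 3 is 2-chloropyridin-4-yl in place of 5-chloropyridin-3-yl on a saturated chain carbon bound to a nitrogen on an aromatic ring: the same atoms, joined differently. Going by the values given here, no measured pair shows this exact rearrangement. The step from compound 1 to compound 2 and the step from compound 1 to compound 3 both show that where the ring nitrogen sits matters, with the two pyridines differing by the step from compound 2 to compound 3. Compound 4 carries its ring nitrogen at yet another position, so only a loose expectation is possible. Compound 4 is therefore expected to land between compound 2 and compound 3, with the step of a 3.6-fold lower number from compound 3 to compound 4 (0.56 log units; beyond the scatter) expected to bring a lower number, and its value in this assay is estimated at 2000 nM, within a range from 250 nM to 15000 nM.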

Compound 4, half-maximal inhibitory concentration: 6900 nM
The estimate for compound 4 lay 3.5-fold (0.54 log units) below the measured number; the range from low to high includes it.
By their numbers in this assay, from the lowest: compound 1; then compound 2; then compounds 4 and 3 (each within the scatter of the next).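

In this assay, the 2-chloropyridin-4-yl and 5-chloropyridin-3-yl groups cannot be told apart at this position on a saturated chain carbon bound to a nitrogen on an aromatic ring, with a 1.0-fold lower number from compound 3 to compound 4 (0.02 log units; within the scatter), so the poor result of compound 3 is no longer confined to a single arrangement of the ring nitrogen and chlorine. The 4-chloropyridin-2-yl group now stands apart from both of these isomers, with a 36-fold higher number from compound 2 to compound 4 (1.56 log units; beyond the scatter), and the 3-chlorophenyl group lies further off still, with a 280-fold higher number from compound 1 to compound 4 (2.44 log units; beyond the scatter); among the three chloropyridines shown, only compound 2 comes within a modest step of compound 1, while all three give higher numbers than compound 1, and none goes against that. No other data shown bear on why the ring nitrogen's placement separates these compounds in this way.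

What the compounds shown leave open is whether a pyrimidine ring at this position would follow the pyridines or the phenyl ring. Also open, going by these compounds, is how a fluorine, a methoxy group or a nitrile in place of the chlorine would fare on these same rings.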